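Chloro on a purine core: from compound 3 to compound 4

The source may hold more compounds than are shown below. What is called first, only, known or untested is meant among the compounds shown, and "the series" means these compounds.

Measured so far in a functional assay on SW480 cells (Homo sapiens) for antiproliferative activity, read by MTT assay, with a stated time of 48 h; a lower number here means a stronger inhibitor, a higher number a weaker inhibitor:
compound 1 `CCCCCC(CCO)n1cnc2c(Cl)ncnc21`, > 50000 nM
compound 2 `CCCCCC(CCO)n1cnc2cncnc21`, > 50000 nM
compound 3 `CCCCCCCCCCC(CCO)n1cnc2c(N)ncnc21`, 1200 nM

The value of compound 1 is a limit of this assay, not a number. The value of compound 2 is likewise a limit of this assay. Compound 1 and compound 2 differ by one change, (chloro in place of hydrogen on an aromatic carbon), and the step that the two limits leave unreadable from compound 2 to compound 1 cannot be read because of the limit of > 50000 nM in this assay, at which 2 of the 3 values shown sit. Compound 3 is the only one of the three with a number in this assay. How the core of compound 3 differs from that of compound 2 is not broken down here.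

Compound 4 `CCCCCCCCCCC(CCO)n1cnc2c(N)nc(Cl)nc21` is not yet measured. It differs from compound 3 by chloro in place of hydrogen on an aromatic carbon. This is the same kind of change as from compound 2 to compound 1, but not the same: in compound 4 the chloro sits between two ring nitrogen atoms, meta to an amino group, meta and para to a fused ring, whereas in compound 1 it sits next to the ring nitrogen, ortho and meta to a fused ring, opposite the ring nitrogen.

Among the compounds with values here, the only measured step of this kind is unreadable, so for compound 4 a modest step is expected, a 1.3-fold higher number from compound 3 to compound 4 (0.10 log units; within the scatter). Compound 4 is expected to give 1500 nM in this assay, likely within 400 nM to 6000 nM.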

Compound 4, half-maximal inhibitory concentration: 13100 nM
Estimate against measurement, compound 4: 8.7-fold (0.94 log units) below; the measured number lies above the stated range.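

In this assay, chloro in place of hydrogen on an aromatic carbon gives an 11-fold higher number from compound 3 to compound 4 (1.04 log units; beyond the scatter), so on the core of compound 3 this change clearly makes for a weaker inhibitor. Within the data shown here, the same kind of change on the core of compound 2, which leads to compound 1, cannot be read, because both compounds give a limit of the assay rather than a number: the limit of > 50000 nM in this assay, at which 2 of the 4 values shown sit. The one readable step therefore comes from a single core with chloro at a single place, between two ring nitrogen atoms, and it does not show that the change would have a similar size, or even the same direction, on another core or at another place.

As far as these compounds go, it remains open whether a fluoro, bromo or methyl group at that same place on the core of compound 3 would give a value close to that of compound 3 or of compound 4. Also open, from the compounds shown here alone, is whether the step would keep its size if the long chain of compound 4 were replaced by the shorter chain of compound 1.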